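Replacing a Thiophene Amide with an Isoxazole Amide

This account rests on a few compounds, and the source may have more. Where it says the series, first, only, none or still open, it means among the compounds named here.

Two compounds sharing a trifluoromethyl-bearing core were characterised in an assay on Jurkat cells for inhibition of nuclear factor NF-kappa-B p105 subunit (Homo sapiens); on this read-out lower numbers stand for stronger inhibition and higher numbers for weaker inhibition. For the measured compounds named here, compound 1 `O=C(Nc1cc(Cl)cc(Cl)c1)c1cncnc1C(F)(F)F` reached only a limit in this assay, > 10000 nM, and that limit stands as the one value beside the single number; the point is summarised as the limit of > 10000 nM in this assay, at which 1 of the 2 values shown sits. Compound 2 `Cc1ccc(NC(=O)c2cnc(Cl)nc2C(F)(F)F)s1` carries a chloro substituent on the core that compound 1 lacks, and in this assay compound 2 gives 2300 nM, the only numerical result in the set, so no comparison within it can be called a step beyond the scatter.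

Compound 3 `Cc1cc(NC(=O)c2cnc(Cl)nc2C(F)(F)F)on1` follows from compound 2 through a single exchange on the amide-type nitrogen, (3-methyl-1,2-oxazol-5-yl in place of 5-methylthiophen-2-yl on an amide-type nitrogen), 3-methyl-1,2-oxazol-5-yl in place of 5-methylthiophen-2-yl. Going by the values given here, no measured pair shows the effect of such an exchange, so the size and direction of the change in this assay cannot be drawn from the data, and a step of modest size in either direction, possibly within the scatter, is the natural expectation.

On that basis compound 3 is estimated at 4000 nM in this assay, within a range from 1000 nM to 20000 nM. The estimated step of a 1.7-fold higher number from compound 2 to compound 3 (0.24 log units; within the scatter) expresses this expectation, with the outcome to be settled by the measurement.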

Compound 3, half-maximal inhibitory concentration: 4000 nM
The estimate for compound 3 equals the measured number at the digits printed; low and high end bracket the measured number.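

In this assay, the group on the amide-type nitrogen now has its first measured exchange: 3-methyl-1,2-oxazol-5-yl in place of 5-methylthiophen-2-yl gives a 1.7-fold higher number from compound 2 to compound 3 (0.24 log units; within the scatter). At this place, then, a five-membered aromatic ring with 1 hetero atom and one with 2 hetero atoms, each with 6 heavy atoms, cannot be told apart on this read-out, and compound 2 and compound 3 stand together as a measured pair. The data shown offer no explanation for this result.

For the compounds shown here, compound 1 stands at a limit, > 10000 nM, and it differs from compound 2 in more than one place, so no step involving it can be read. From the compounds shown here alone, it remains open whether other groups on this nitrogen, such as a phenyl ring carrying a carboxylic acid or an open alkyl chain, would move the number beyond the scatter, and what an amine in place of the chloro substituent on the shared core would do with either five-membered ring.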